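This account rests on a few compounds, and the source may have more. Where it says the series, first, only, none or still open, it means among the compounds named here.

Compound 1 `O=C(/C(=C\c1ccc(O)cc1)SCc1ccc(Cl)cc1)c1ccc(Br)cc1`: 10000 nM
Compound 2 `O=C(/C(=C\c1ccc(O)cc1)SCc1ccc(F)cc1)c1ccc(Br)cc1`: 10000 nM
Compound 3 `CN(C)c1ccc(/C=C(/SCc2ccc(F)cc2)C(=O)c2ccc(Cl)cc2)cc1`: 50000 nM

In a functional assay on DU-145 cells (Homo sapiens) for inhibition, read by trypan blue exclusion, with a stated time of 96 h (on this read-out lower numbers stand for stronger inhibition of growth and higher numbers for weaker inhibition of growth), compound 1 gives 10000 nM, level with compound 2 and together with it the lowest of the three numbers, while compound 3 gives 50000 nM, a higher number. Among the measured compounds shown here, the only single-place step measured, no change at the digits printed from compound 1 to compound 2 (within the scatter), swaps one halogen for another and stays within the scatter. Compound 4 `O=C(/C(=C\c1ccc(Br)cc1)SCc1ccc(Cl)cc1)c1ccc(Br)cc1` differs from compound 1 by bromo in place of hydroxy on an aromatic carbon. For the measured compounds named here, no measured step exchanges a hydroxy for a bromo, so the one known step offers no direct guide, and no step beyond the scatter is expected in this assay. Compound 4 is therefore estimated at 10000 nM, with a range from 4000 nM to 30000 nM, an expected step of no change at the digits printed from compound 1 to compound 4 (within the scatter).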

Compound 4, concentration for 50% growth inhibition: 1000 nM
Compound 4: middle estimate off by 10-fold (1.00 log units), on the high side, outside the stated range (below it).
By their numbers in this assay, from the lowest: compound 4; then compounds 1 and 2 (each within the scatter of the next); then compound 3.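

In this assay, this position on the 4-hydroxyphenyl group proves sensitive to what it carries: bromo in place of hydroxy gives a 10-fold lower number from compound 1 to compound 4 (1.00 log units; beyond the scatter), a step beyond the scatter. Among the compounds shown here, the only earlier step, the halogen swap, gave no change at the digits printed from compound 1 to compound 2 (within the scatter), so this is the first sign that a single change can shift the number. No measured evidence accounts for this step.

The compounds shown leave open whether bromo itself matters or simply the loss of hydroxy. A methoxy group or a carboxylic acid at this place would be needed to tell these apart.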